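A few compounds are considered here, and "the series" means these few. Any claim that something is new, unique, unknown or untested is made for them only; others in the source may bear on it.

Hot plate series, values in a functional assay on the whole organism with Mus musculus as the target, in the hot plate test; on this read-out higher numbers stand for an effect only at larger amounts of compound and lower numbers for an effect already at smaller amounts:
compound 1 `Cc1ccc(C(=O)OC2CCN(C)CC2)cc1`: 18.2 mg/kg
compound 2 `CN1CCC(OC(=O)c2ccc(C(C)(C)C)cc2)CC1`: 23.3 mg/kg
compound 3 `COc1cc(OC)c(C(=O)OC2CCN(C)CC2)c(OC)c1`: 11.6 mg/kg

Compound 2 gives the largest of the three numbers in this assay, but its gaps to compound 1 and to compound 3 both lie within the scatter, so the three compounds are not separated. Compound 4 `CN1CCC(OC(=O)c2ccc(F)cc2)CC1` differs from compound 2 by fluoro in place of tert-butyl on an aromatic carbon. Within the data shown here, only one measured step touches this position, a 1.3-fold higher number from compound 1 to compound 2 (0.11 log units; within the scatter), and it stayed within the scatter; compound 3 differs from compound 2 in more than one place and does not bear on the change. A step no larger than the scatter is therefore expected in this assay, a 1.3-fold lower number from compound 2 to compound 4 (0.11 log units; within the scatter). For compound 4 the estimate is 18 mg/kg, with a range from 9 mg/kg to 40 mg/kg.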

Compound 4, dose for half-maximal effect: 11.5 mg/kg
Compound 4: middle estimate off by 1.6-fold (0.19 log units), on the high side, and the stated range covers the measured number.
By their numbers in this assay, from the lowest: compounds 4, 3, 1 and 2 (each within the scatter of the next, the first and the last beyond it).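

Among these compounds, this position is not silent in this assay: fluoro in place of tert-butyl gives the first step beyond the scatter, though a modest one (a 2.0-fold lower number from compound 2 to compound 4 (0.31 log units; beyond the scatter)). Fluoro in place of methyl stays within the scatter (a 1.6-fold lower number from compound 1 to compound 4 (0.20 log units; within the scatter)), so among these three groups only the pair furthest apart in heavy atoms, 4 against 1, is separated. No available evidence gives a reason for this step.

Still open, going by these compounds, is whether the numbers follow heavy atom count beyond these groups, for example with chloro or ethyl at this place. An amine or a carboxylic acid here remains untested in the compounds shown.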